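The source may report more compounds than this note shows. Statements on the series, on what has been measured and on what is new or still open speak of the compounds shown alone.

Working notes on the series. In a functional assay on U-87MG ATCC cells for antiproliferative activity against U-87 MG (Homo sapiens), read by MTT assay, with a stated time of 48 h (on this read-out lower numbers stand for stronger inhibition and higher numbers for weaker inhibition), compound 1 `Cc1nc(-c2ccc(Cl)cc2)sc1C(=O)CSc1nc(N)c(C#N)c(-c2ccc(Cl)cc2)n1` gives 3420 nM, compound 2 `Cc1nc(-c2ccccc2)sc1C(=O)CSc1nc(-c2ccccc2)c(C#N)c(=O)[nH]1` gives 56600 nM and compound 3 `Cc1nc(-c2ccc(Cl)cc2)sc1C(=O)CSc1nc(-c2ccccc2)c(C#N)c(=O)[nH]1` gives 27600 nM. Compound 3 stands second highest of the three numbers in this assay: its nearest neighbour is compound 2, with the higher number, and its furthest is compound 1, with the lower number. Compounds 1 and 3 differ in more than one place, so their two values are only set side by side. Among the measured compounds shown here, the single measured one-place step, a 2.1-fold lower number from compound 2 to compound 3 (0.31 log units; beyond the scatter), concerns chloro in place of hydrogen on the aromatic ring attached to the thiazole of the shared core.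

Compound 4 `Cc1nc(-c2ccc(Cl)cc2)sc1C(=O)CSc1nc(-c2cccc(Cl)c2)c(C#N)c(=O)[nH]1` has not yet been measured in this assay. It differs from compound 3 as follows: chloro in place of hydrogen on an aromatic carbon, that is, phenyl to 3-chlorophenyl on the other aromatic ring. The step from compound 2 to compound 3 is the only one that bears on it, being the same kind of substitution on a different ring; it was modest and just beyond the scatter. A lowering of similar, modest size is therefore expected in this assay, with the caveat that one example on another ring is thin support. Compound 4 is expected at about 15000 nM, in the range 6000 nM to 40000 nM. That estimate corresponds to an expected 1.8-fold lower number from compound 3 to compound 4 (0.26 log units; within the scatter).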

Compound 4, half-maximal inhibitory concentration: 40100 nM
The estimate for compound 4 lay 2.7-fold (0.43 log units) below the measured number, outside the stated range (above it).
By their numbers in this assay, from the lowest: compound 1; then compounds 3, 4 and 2 (each within the scatter of the next, the first and the last beyond it).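

In this assay, chloro in place of hydrogen on this ring, phenyl to 3-chlorophenyl, gives a 1.5-fold higher number from compound 3 to compound 4 (0.16 log units; within the scatter), so at this place the exchange cannot be told apart from repeat measurement. The same kind of exchange on the aromatic ring attached to the thiazole gave a 2.1-fold lower number from compound 2 to compound 3 (0.31 log units; beyond the scatter), which lies beyond the scatter, so across these two steps a modest shift on one ring does not carry over to a shift beyond the scatter on the other, although each ring is represented by a single example. Nothing available on these compounds accounts for this result.

The compounds shown leave open whether any other group at this place, such as a methoxy group, an amine or a carboxylic acid, would move the number beyond the scatter, and whether chloro elsewhere on the same ring would behave as it does here. They also leave open which of its several differences from compound 4 sets compound 1 apart, since those two compounds differ in more than one place and no single change can be isolated between them.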